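A few compounds are considered here, and "the series" means these few. Any claim that something is new, unique, unknown or untested is made for them only; others in the source may bear on it.

Measured in a functional assay on A549 cells (Homo sapiens) for inhibition, read by MTT assay, with a stated time of 48 h; on this read-out lower numbers stand for stronger inhibition and higher numbers for weaker inhibition:
- Compound 1 `COc1cc(-c2nccn3cc(-c4ccc(Cl)cc4)nc23)cc(OC)c1OC`: 7290 nM
- Compound 2 `COc1cc(-c2nccn3cc(-c4ccc(N)cc4)nc23)cc(OC)c1OC`: 287 nM

Only these two compounds have been measured so far. Compound 2 has the lower number, at 287 nM, so it is the stronger inhibitor of the pair in this assay. The next compound, compound 3 `COc1cc(-c2nccn3cc(-c4ccc(O)cc4)nc23)cc(OC)c1OC`, keeps the shared core and changes one group: hydroxy in place of amino on an aromatic carbon. In words, hydroxy takes the place of amino on an aromatic carbon, turning 4-aminophenyl into 4-hydroxyphenyl.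

Among the measured compounds shown here, only one measured step bears on this change. It involves the same place on the molecule: a 25-fold lower number from compound 1 to compound 2 (1.40 log units; beyond the scatter), a large step, well beyond the scatter, made by putting amino in place of chloro. For the measured compounds named here, that step shows that a swap at this place can move the number considerably, but no measurement yet shows what hydroxy does here. The counts for hydroxy and amino match, so a moderate move towards a higher number is expected, smaller than the step seen for compound 2 287 nM. The expected change is a 1.9-fold higher number from compound 2 to compound 3 (0.28 log units; within the scatter). For compound 3 the estimated value is 550 nM, with an expected range of 130 nM to 2500 nM.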

Compound 3, half-maximal inhibitory concentration: > 10000 nM
Compound 3: a limit, no number; the forecaster's own chance of this, stated with the estimate: 3%; at least 18-fold (1.25 log units) between middle value and limit.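

In this assay, compound 3 gives a limit and not a number: the limit of > 10000 nM in this assay, at which 1 of the 3 values shown sits. Replacing amino with hydroxy swaps a single nitrogen for a single oxygen and leaves the counts of heavy atoms, hydrogen-bond donors and hydrogen-bond acceptors unchanged, yet it gives an at least 34-fold higher number from compound 2 to compound 3 (1.54 log units; beyond the scatter), so at this position those matching counts say little about the outcome. Compared with chloro, hydroxy gives an at least 1.3-fold higher number from compound 1 to compound 3 (0.13 log units; that floor lies within the scatter), so these data do not separate the two groups, and amino alone stands apart among the three, with compound 2 holding the lowest number by steps beyond the scatter on both sides.

The compounds shown leave open whether the low number depends on the free amino group itself, a question that methylamino, dimethylamino or acetamide at the same carbon could help to answer, while methoxy would extend the comparison with hydroxy. They also leave open how far compound 3 lies beyond its limit, and whether the gain seen with amino would carry over to a different core.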